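Thiourea series: ring swap step and expected compound 4

A few compounds are considered here, and "the series" means these few. Any claim that something is new, unique, unknown or untested is made for them only; others in the source may bear on it.

Measured compounds in a functional assay on HCT-116 cells (Homo sapiens) for cytotoxicity, read by MTT assay, with a stated time of 48 h; a higher number here means a weaker inhibitor, a lower number a stronger inhibitor:
compound 1, `CNC(=O)c1ccc(Sc2cccc(NC(=S)Nc3ccc(F)c(F)c3)c2)nc1`, 35100 nM
compound 2, `CNC(=O)c1ccc(Sc2cccc(NC(=S)Nc3cccc(C(F)(F)F)c3)c2)nc1`, 16200 nM
compound 3, `CNC(=O)c1ccc(Sc2ccc(NC(=S)Nc3ccc(F)c(F)c3)cc2)nc1`, 22200 nM

Compounds 1 and 2 share one core and compounds 3 and 4 share another; the two cores are built from the same atoms joined differently, and the difference between the two cores is not broken down here. Among the compounds with values here, the only counted change within each pair is 3-(trifluoromethyl)phenyl in place of 3,4-difluorophenyl on an amide-type nitrogen, and the same change, (3-(trifluoromethyl)phenyl in place of 3,4-difluorophenyl on an amide-type nitrogen), leads from compound 3 to the unmeasured compound 4, `CNC(=O)c1ccc(Sc2ccc(NC(=S)Nc3cccc(C(F)(F)F)c3)cc2)nc1`. The place is worded identically for both pairs, so the change is taken as the same one.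

In this assay the measured step is a 2.2-fold lower number from compound 1 to compound 2 (0.34 log units; beyond the scatter). Compound 3 and compound 2 are within the scatter of each other, as are compound 3 and compound 1, so nothing is said of their order.

Within the data shown here, for compound 4 the expectation rests on the single measured step of a 2.2-fold lower number from compound 1 to compound 2 (0.34 log units; beyond the scatter) carried over to the core of compound 3, whose value is 22200 nM. The step from compound 3 to compound 4 is expected to be about a 2.2-fold lower number from compound 3 to compound 4 (0.35 log units; beyond the scatter), matching the size of the earlier one. Compound 4 is therefore estimated at 10000 nM, with a likely range from 5000 nM to 25000 nM; with one precedent only, the range is kept wide.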

Compound 4, half-maximal inhibitory concentration: 25900 nM
The estimate for compound 4 lay 2.6-fold (0.41 log units) below the measured number, outside the stated range (above it).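

In this assay, placing 3-(trifluoromethyl)phenyl instead of 3,4-difluorophenyl on the amide-type nitrogen of the second core gives a 1.2-fold higher number from compound 3 to compound 4 (0.07 log units; within the scatter), so on this core the change cannot be told apart from no effect. The lower number seen on the first core therefore does not return as a step beyond the scatter, yet the two steps cannot be called different: the same change on two cores in this assay, a 2.2-fold lower number (0.34 log units; beyond the scatter) from compound 1 to compound 2 and a 1.2-fold higher number (0.07 log units; within the scatter) from compound 3 to compound 4, 2.5-fold (0.40 log units) apart, within the scatter of two such steps. Going by these compounds, this pair shows neither that the change carries over between the two cores with its size intact nor that the core alters its effect, and with a single step on each core both readings remain open, so the earlier step gives little guidance for this core.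

The compounds shown leave open how other groups on the same nitrogen would behave across the two cores, for example an unsubstituted phenyl, a cyclohexyl or a short alkyl chain. They also leave open whether the comparison would hold with a carbonyl in place of the thiocarbonyl, or with a carboxylic acid in place of the N-methyl amide, in this assay or in any other read-out.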